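The source may hold more compounds than are shown below. What is called first, only, known or untested is meant among the compounds shown, and "the series" means these compounds.

Compound 2 `Cc1ccc(C)c(-n2nncc2CN2C(=O)C3(C(C#N)=C(N)Oc4c3c3nc5ccccc5nc3c3ccccc43)c3ccccc32)c1` has been tested in an ADME assay on L02 cells (Homo sapiens) for antiproliferative activity, read by MTT assay, with a stated time of 48 h; a higher number here means a weaker inhibitor, a lower number a stronger inhibitor. For compound 2 the result is only a limit, > 50000 nM, which is the limit of > 50000 nM in this assay, at which 1 of the 2 values shown sits. Among the measured compounds shown here, compound 1 `N#CC1=C(N)Oc2c(c3nc4ccccc4nc3c3ccccc23)C12C(=O)N(Cc1cnnn1-c1cccc(Cl)c1)c1ccccc12` gives 35200 nM in this assay, and the one measured step that bears on the present question is an at least 1.4-fold higher number from compound 1 to compound 2 (0.15 log units; that floor lies within the scatter). Compound 3 `N#CC1=C(N)Oc2c(c3nc4ccccc4nc3c3ccccc23)C12C(=O)N(Cc1cnnn1-c1cc(Cl)ccc1Cl)c1ccccc12` differs from compound 2 by 2,5-dichlorophenyl in place of 2,5-dimethylphenyl on an aromatic nitrogen. Because an at least 1.4-fold higher number from compound 1 to compound 2 (0.15 log units; that floor lies within the scatter) stays within the scatter, the expected step of an at least 1.1-fold lower number from compound 2 to compound 3 (0.07 log units; that floor lies within the scatter) is small and without a clear direction. Compound 3 is therefore estimated at 42000 nM, within a range from 20000 nM to 90000 nM, and may again come out as a limit.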

Compound 3, half-maximal inhibitory concentration: > 50000 nM
Compound 3 was reported as a limit; the forecaster's own chance of this, stated with the estimate: 45%; middle value at least 1.1-fold (0.07 log units) away from the limit.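

In this assay, no step can be read between compound 2 and compound 3, because both are reported only as limits: the limit of > 50000 nM in this assay, at which 2 of the 3 values shown sit. Placing chloro on an aromatic carbon in place of hydrogen gives an at least 1.4-fold higher number from compound 1 to compound 3 (0.15 log units; that floor lies within the scatter), so this change shows no step beyond the scatter. Swapping 2,5-dimethylphenyl for 2,5-dichlorophenyl on this aromatic nitrogen still yields a limit, not a number.

As far as these compounds go, whether a phenyl carrying an amine or a carboxylic acid at this place would give a readable number stays open. From the compounds shown here alone, the true numbers of compound 2 and compound 3 also remain unknown.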